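Replacing pyridin-2-yl with (ethylsulfonyl)amino on the core

The source may hold more compounds than are shown below. What is called first, only, known or untested is meant among the compounds shown, and "the series" means these compounds.

Compound 1 `Cc1n[nH]cc1-c1cccc2c1CCC2c1ncc[nH]1` gives 634 nM in a functional assay on CHO cells for agonist activity at Alpha-1D adrenergic receptor (Homo sapiens), read by FLIPR and calcium flux; a lower number here means that less compound is needed, a higher number that more compound is needed for the effect.
Compound 2 `c1ccc(-c2cccc3c2CCC3c2ncc[nH]2)nc1` gives only a limit in this assay, > 10000 nM.
Compound 3 `Cn1ccc(-c2cccc3c2CCC3c2ncc[nH]2)n1` likewise gives only a limit in this assay, > 10000 nM.

Compound 2 stands at the limit of this assay rather than at a number; it shares this with compound 3, as the line the limit of > 10000 nM in this assay, at which 2 of the 3 values shown sit, shows. The step from compound 2 to compound 4 `CCS(=O)(=O)Nc1cccc2c1CCC2c1ncc[nH]1` replaces the pyridin-2-yl group with (ethylsulfonyl)amino: (ethylsulfonyl)amino in place of pyridin-2-yl on an aromatic carbon. Among the measured steps, only those starting from compound 1 are readable: an at least 15-fold higher number from compound 1 to compound 2 (1.19 log units; beyond the scatter) and an at least 15-fold higher number from compound 1 to compound 3 (1.19 log units; beyond the scatter), both large and both away from the one group carrying a hydrogen-bond donor. The step from compound 2 to compound 3 is not readable, since both sit at the limit. The entering (ethylsulfonyl)amino brings back 1 hydrogen-bond donor, so compound 4 is expected to fall below the limit, though not to reach compound 1. For compound 4 the estimate in this assay is 3000 nM, with a range from 500 nM to 15000 nM, which is expected to correspond to an at least 3.3-fold lower number from compound 2 to compound 4 (0.52 log units; beyond the scatter).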

Compound 4, half-maximal effective concentration: > 10000 nM
Compound 4: only a limit was reported (the forecaster's own chance of this, stated with the estimate: 40%); middle value at least 3.3-fold (0.52 log units) away from the limit.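

In this assay compound 4 also gives only a limit and not a number, so the steps among compounds 2, 3 and 4 cannot be read, and all three stand together: the limit of > 10000 nM in this assay, at which 3 of the 4 values shown sit.

Going by these compounds alone, the one readable new step is an at least 15-fold higher number from compound 1 to compound 4 (1.19 log units; beyond the scatter), with (ethylsulfonyl)amino in place of 3-methyl-1H-pyrazol-4-yl on an aromatic carbon. Thus a hydrogen-bond donor on this aromatic carbon is not enough on its own to give a readable value, since (ethylsulfonyl)amino carries one and has no ring; of the four compounds, only compound 1 gives a number, 634 nM.

As far as these compounds go, whether any differences among compounds 2, 3 and 4 lie hidden behind their limits stays open. From the compounds shown here alone, it is also open whether an amine or a 1H-pyrazol-4-yl group without the methyl on the same aromatic carbon would give a number in this assay.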